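The source may hold more compounds than are shown below. What is called first, only, known or untested is meant among the compounds shown, and "the series" means these compounds.

Two closely related compounds have been tested so far. Compound 1 `Fc1ccccc1/C=C/c1ccccc1` gives 700 nM in an assay on HepG2 cells for activation of nuclear factor erythroid 2-related factor 2 (Homo sapiens), read by a luciferase reporter, with a stated time of 5 h (on this read-out higher numbers stand for an effect only at larger amounts of compound and lower numbers for an effect already at smaller amounts), while compound 2 `Fc1cccc(/C=C/c2ccccc2)c1` gives 3100 nM in this assay, the higher of the two numbers, and the gap between them lies beyond the usual scatter. Compound 3 `Cc1ccc(/C=C/c2cccc(F)c2)cc1` differs from compound 2 by methyl in place of hydrogen on an aromatic carbon. Within the data shown here, no measured pair shows what this change does here, so only a small step is expected in this assay, if any, with compound 2 as the anchor and the step from compound 2 to compound 3 estimated at a 1.4-fold lower number from compound 2 to compound 3 (0.15 log units; within the scatter). Compound 3 is therefore expected to give about 2200 nM, within a range from 700 nM to 7000 nM.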

Compound 3, half-maximal effective concentration: 800 nM
Compound 3: the middle estimate sits 2.8-fold (0.44 log units) above what was measured, within the range that was stated.
By their numbers in this assay, from the lowest: compounds 1 and 3 (each within the scatter of the next); then compound 2.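

In this assay, methyl in place of hydrogen on an aromatic carbon gives a 3.9-fold lower number from compound 2 to compound 3 (0.59 log units; beyond the scatter). Among these compounds, this is the first measured step at this position, para to a group of 9 heavy atoms, and it shows that a single added carbon there can lower the number by more than the scatter. Nothing available explains this effect. Open questions are whether an ethyl chain, an amine or a carboxylic acid at the same place would lower the number further or raise it, and whether methyl acts likewise on the core of compound 1.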